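The source may hold more compounds than are shown below. What is called first, only, known or untested is meant among the compounds shown, and "the series" means these compounds.

The measured compounds in a functional assay on 2008 cells (Homo sapiens) for cytotoxicity, read by MTT assay, with a stated time of 68 h; a higher number here means a weaker inhibitor, a lower number a stronger inhibitor:
Compound 1, `O=C(/C=C/c1cccc(OCc2ccccc2)c1)c1ccc(Br)cc1`: compound 1 gives 1000 nM.
Compound 2, `COc1ccc(C(=O)/C=C/c2cccc(OCc3ccccc3)c2)cc1`: compound 2 gives 17200 nM.
Compound 3, `O=C(/C=C/c1cccc(OCc2ccccc2)c1)c1cccc(Br)c1`: compound 3 gives 5700 nM.

Compound 3 stands second highest of the three numbers in this assay. Its nearest neighbour is compound 2, the step being a 3.0-fold lower number from compound 2 to compound 3 (0.48 log units; beyond the scatter); furthest away is compound 1, with a 5.7-fold higher number from compound 1 to compound 3 (0.76 log units; beyond the scatter) separating them. Compound 4, `O=C(/C=C/c1cccc(OCc2ccccc2)c1)c1ccc(Cl)cc1Cl`, is not yet measured and differs from compound 3 by 2,4-dichlorophenyl in place of 3-bromophenyl on a carbonyl carbon.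

Among the compounds with values here, two measured steps bear on this change. The step of a 5.7-fold higher number from compound 1 to compound 3 (0.76 log units; beyond the scatter) shows that the bromo-bearing ring on the carbonyl carbon gives a modestly stronger inhibitor as 4-bromophenyl than as 3-bromophenyl. The step of a 17-fold higher number from compound 1 to compound 2 (1.24 log units; beyond the scatter) shows a large weakening when methoxy stands in place of bromo. No measured compound carries two halogens on this ring, so what the second chlorine adds is not shown. Because compound 1 gives 1000 nM with a halogen in a 4-substituted ring, compound 4 is expected to return part of the way toward it, a step of a 2.6-fold lower number from compound 3 to compound 4 (0.41 log units; beyond the scatter). Compound 4 is therefore estimated at 2200 nM, within 600 nM to 8000 nM.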

Compound 4, half-maximal inhibitory concentration: 5200 nM
For compound 4 the middle estimate is 2.4-fold (0.37 log units) below the measured one, and the stated range covers the measured number.
By their numbers in this assay, from the lowest: compound 1; then compounds 4 and 3 (each within the scatter of the next); then compound 2.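

In this assay, the 2,4-dichlorophenyl group on the carbonyl carbon cannot be told apart from 3-bromophenyl (the step is a 1.1-fold lower number from compound 3 to compound 4 (0.04 log units; within the scatter)), yet it gives a stronger inhibitor than 4-methoxyphenyl (a 3.3-fold lower number from compound 2 to compound 4 (0.52 log units; beyond the scatter)) and a weaker one than 4-bromophenyl (a 5.2-fold higher number from compound 1 to compound 4 (0.72 log units; beyond the scatter)). Carrying halogen on this ring is thus not enough to reach the level of compound 1, which stands alone at the low end of the numbers, with compound 3 and compound 4 both halogen-bearing and both well short of it. Nothing shown here gives a reason for these differences.

What the second chlorine contributes remains open, since no ring with a single chlorine stands among these compounds. Equally open, as far as these compounds go, is how a ring carrying an amine or a carboxylic acid on this carbonyl carbon would compare with compound 1.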